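Quinoline amide series: chlorophenyl carbonyl placement, compound 4

A few compounds are considered here, and "the series" means these few. Any claim that something is new, unique, unknown or untested is made for them only; others in the source may bear on it.

Measured compounds:
compound 1 `O=C(Nc1ccccc1C(F)(F)F)C1CCc2ccccc2N1C(=O)c1ccccc1` — 8090 nM
compound 2 `O=C(Nc1ccccc1C(F)(F)F)C1CCc2ccccc2N1C(=O)c1ccccc1Cl` — 3900 nM
compound 3 `O=C(Nc1ccccc1O)C1CCc2ccccc2N1C(=O)c1ccccc1Cl` — 44200 nM

All three were run in a functional assay on ACHN cells (Homo sapiens) for cytotoxicity, read by sulforhodamine B assay, with a stated time of 72 h; on this read-out lower numbers stand for stronger inhibition of growth and higher numbers for weaker inhibition of growth. Compound 2 stands lowest of the three numbers: the nearest is compound 1, with a 2.1-fold lower number from compound 1 to compound 2 (0.32 log units; beyond the scatter) separating them, and the furthest is compound 3, reached by an 11-fold higher number from compound 2 to compound 3 (1.05 log units; beyond the scatter). Compound 4 `O=C(Nc1ccccc1C(F)(F)F)C1CCc2ccccc2N1C(=O)c1ccc(Cl)cc1` has not been measured. It differs from compound 2 in one place: 4-chlorophenyl in place of 2-chlorophenyl on a carbonyl carbon. The two have the same atoms, joined differently.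

Within the data shown here, no measured step moves a chlorine from one position of the phenyl to another. The step from compound 1 to compound 2 shows only that adding the chlorine brings a modest gain; the step from compound 2 to compound 3 concerns a different ring altogether. There is therefore no measured basis for a large step in either direction, and the expectation is a change close to or within the scatter. Compound 4 is estimated at 5500 nM, with a range of 2200 nM to 14000 nM. The implied step is expected to be a 1.4-fold higher number from compound 2 to compound 4 (0.15 log units; within the scatter), with some lean toward the number of compound 1 because of 8090 nM being the unsubstituted comparator.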

Compound 4, concentration for 50% growth inhibition: 824 nM
Compound 4: the middle estimate sits 6.7-fold (0.82 log units) above what was measured; the measured number lies below the stated range.
By their numbers in this assay, from the lowest: compound 4; then compound 2; then compound 1; then compound 3.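

In this assay, moving the chlorine alone counts: with the same atoms, 4-chlorophenyl in place of 2-chlorophenyl on the carbonyl carbon gives a 4.7-fold lower number from compound 2 to compound 4 (0.68 log units; beyond the scatter). The gain from adding a chlorine to the unsubstituted phenyl therefore depends on where it stands, with 2-chlorophenyl giving a 2.1-fold lower number from compound 1 to compound 2 (0.32 log units; beyond the scatter) and 4-chlorophenyl giving a 9.8-fold lower number from compound 1 to compound 4 (0.99 log units; beyond the scatter). No measurement shown here accounts for this difference between the two placements.

Open, going by these compounds, is whether a methoxy, an amine or a carboxylic acid in place of the chlorine of the 4-chlorophenyl would hold the number of compound 4, 824 nM. Also open, on these data alone, is whether hydroxy in place of trifluoromethyl costs as much alongside the 4-chlorophenyl as it does alongside the 2-chlorophenyl, where it gives an 11-fold higher number from compound 2 to compound 3 (1.05 log units; beyond the scatter).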